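The source may hold more compounds than are shown below. What is called first, only, known or untested is meant among the compounds shown, and "the series" means these compounds.

Compound 1 `Cc1ccc(-n2nncc2CN2C(=O)C3(C(C#N)=C(N)Oc4c(N)cc5nc6ccccc6nc5c43)c3ccccc32)cc1C` gives > 50000 nM in an ADME assay on L02 cells (Homo sapiens) for antiproliferative activity, read by MTT assay, with a stated time of 48 h; on this read-out higher numbers stand for weaker inhibition and lower numbers for stronger inhibition; this is a limit of the assay, not a number.
Compound 2 `CCc1cccc(C)c1-n1nncc1CN1C(=O)C2(C(C#N)=C(N)Oc3c(N)cc4nc5ccccc5nc4c32)c2ccccc21` gives > 50000 nM in this assay, again a limit.
Compound 3 `Cc1ccc(C)c(-n2nncc2CN2C(=O)C3(C(C#N)=C(N)Oc4c(N)cc5nc6ccccc6nc5c43)c3ccccc32)c1` gives > 50000 nM in this assay, once more a limit.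

Compound 3 therefore stands at the limit shared by every measured compound (the limit of > 50000 nM in this assay, at which 3 of the 3 values shown sit); no number places it stronger or weaker than the other two. Compound 4 `Cc1ccc(-n2nncc2CN2C(=O)C3(C(C#N)=C(N)Oc4c(N)cc5nc6ccccc6nc5c43)c3ccccc32)cc1Cl` differs from compound 3 in one place: 3-chloro-4-methylphenyl in place of 2,5-dimethylphenyl on an aromatic nitrogen. The measured steps that touch the same position are a step that the two limits leave unreadable from compound 1 to compound 3 and a step that the two limits leave unreadable from compound 2 to compound 3, and neither can be read, since both ends of each sit at the limit; the same is true of a step that the two limits leave unreadable from compound 1 to compound 2. Three different aryl groups on the ring nitrogen have so far left this assay reporting only the limit, so the exchange of two methyl groups for a chlorine and a methyl on the same aryl ring gives no ground to expect a readable step. Compound 4 is expected to show a step that the limit leaves unreadable from compound 3 to compound 4 that does not rise beyond the scatter. Compound 4 is estimated at 70000 nM, within a range from 30000 nM to 250000 nM, and most probably the assay will again report only a limit rather than a number.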

Compound 4, half-maximal inhibitory concentration: > 50000 nM
Compound 4 gave a limit, no number; the forecaster's own chance of this, stated with the estimate: 85%; the middle value lies beyond the limit too.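

Compound 4 gives only a limit, not a number, as do compound 1, compound 2 and compound 3, so no step among these four compounds can be read in this assay: the limit of > 50000 nM in this assay, at which 4 of the 4 values shown sit.

The compounds shown leave open how the four aryl groups on the ring nitrogen compare, and whether any aryl group there would give a number in this assay.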